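The source may hold more compounds than are shown below. What is called first, only, known or untested is meant among the compounds shown, and "the series" means these compounds.

In a functional assay on MCF7 cells (Homo sapiens) for inhibition, read by sulforhodamine B assay (a higher number here means a weaker inhibitor of growth, a lower number a stronger inhibitor of growth), compound 1 (`Cc1ccc2[nH]c(-c3ccc(-c4ccc(-c5ccc(N(C)C)cc5)cc4)cc3)nc2c1`) gives 3130 nM, compound 2 (`Cc1ccc2[nH]c(-c3ccc(-c4ccc(-c5cccc(Cl)c5)cc4)cc3)nc2c1`) gives 1210 nM, and compound 3 (`Cc1ccc2[nH]c(-c3ccc(-c4ccc(-c5ccc(F)cc5)cc4)cc3)nc2c1`) gives 30200 nM, the highest of the three numbers. Compound 4 (`Cc1ccc2[nH]c(-c3ccc(-c4ccc(-c5ccc(C(F)(F)F)cc5)cc4)cc3)nc2c1`) has trifluoromethyl in place of fluoro on an aromatic carbon, para to a large group: trifluoromethyl in place of fluoro on an aromatic carbon. The closest measured exchange at this place is dimethylamino to fluoro, a 9.6-fold higher number from compound 1 to compound 3 (0.98 log units; beyond the scatter), a modest step. The step of a 25-fold higher number from compound 2 to compound 3 (1.40 log units; beyond the scatter) is large, but it replaces 3-chlorophenyl with 4-fluorophenyl and so bears less directly on this change. For the measured compounds named here, neither of the other measured compounds carries trifluoromethyl, so the direction rests only on compound 3 having the highest number so far. A modest fall in the number is expected, and the estimated step is a 5.0-fold lower number from compound 3 to compound 4 (0.70 log units; beyond the scatter). Compound 4 is estimated at 6000 nM, with an expected range from 1300 nM to 28000 nM.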

Compound 4, concentration for 50% growth inhibition: 31000 nM
Beside the measured number, compound 4's estimate is 5.2-fold (0.71 log units) below it; the whole stated range lies below it.
By their numbers in this assay, from the lowest: compound 2; then compound 1; then compounds 3 and 4 (each within the scatter of the next).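

In this assay, trifluoromethyl in place of fluoro on this aromatic carbon leaves the number unchanged within the scatter, a 1.0-fold higher number from compound 3 to compound 4 (0.01 log units; within the scatter), so the two groups cannot be told apart at this position. The gaps to the other two compounds therefore hold with trifluoromethyl as they did with fluoro, at a 9.9-fold higher number from compound 1 to compound 4 (1.00 log units; beyond the scatter) and, as a large step, a 26-fold higher number from compound 2 to compound 4 (1.41 log units; beyond the scatter). No evidence is available on why fluoro and trifluoromethyl read alike here.

Compound 2 differs from compound 3 in both the halogen and its place on the ring, so these compounds do not show which of the two accounts for its lower number. Going by these compounds, how a carboxylic acid or a piperazine at this place would read, and whether dimethylamino's lower number extends to other amines, also remains open.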